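The source may report more compounds than this note shows. Statements on the series, on what has been measured and on what is new or still open speak of the compounds shown alone.

The starting point is compound 1, `C/C=C1/[C@H](O[C@@H]2O[C@H](CO)[C@@H](O)[C@H](O)[C@H]2O)OC=C(C(=O)OC)[C@H]1CC(=O)OCCc1ccc2c(c1)OCCO2`, tested in a functional assay on SK-BR-3 cells (Homo sapiens) for antiproliferative activity, read by MTT assay, with a stated time of 72 h; on this read-out lower numbers stand for stronger inhibition and higher numbers for weaker inhibition. In this assay compound 1 gives > 20000 nM, which is a limit of the assay and not a measured number. For the measured compounds named here, the only other compound tested so far is compound 2, `C/C=C1/[C@H](O[C@@H]2O[C@H](COC(C)=O)[C@@H](OC(C)=O)[C@H](OC(C)=O)[C@H]2OC(C)=O)OC=C(C(=O)OC)[C@H]1CC(=O)O`. In this assay compound 2 gives > 15000 nM, which is also a limit. Going by the values given here, neither compound provides an exact number, and no measured step between closely related compounds is available as a guide.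

The next compound is compound 3, `C/C=C1/[C@H](O[C@@H]2O[C@H](CO)[C@@H](O)[C@H](O)[C@H]2O)OC=C(C(=O)OC)[C@H]1CC(=O)OCCC1CCCCC1`, which keeps the core of compound 1 and changes one group: cyclohexyl in place of 2,3-dihydro-1,4-benzodioxin-6-yl on a saturated chain carbon, two bonds along the chain from an oxygen next to a carbonyl group. The expectation rests on compound 1, whose only reading is the limit > 20000 nM. Nothing measured points to a gain, so no shift beyond the usual scatter is expected in this assay, and the estimated change is a step that the limit leaves unreadable from compound 1 to compound 3. For compound 3 the expected value is 25000 nM, with an estimated range from 10000 nM to 60000 nM.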

Compound 3, half-maximal inhibitory concentration: 2000 nM
Beside the measured number, compound 3's estimate is 13-fold (1.10 log units) above it; the measured number lies below the stated range.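

The chain end at this position clearly affects the read-out: in this assay, cyclohexyl in place of 2,3-dihydro-1,4-benzodioxin-6-yl, on a saturated chain carbon, two bonds along the chain from an oxygen next to a carbonyl group, gives an at least 10-fold lower number from compound 1 to compound 3 (1.00 log units; beyond the scatter). This step marks only the smallest change the data allow, not its exact size, because its starting point is a limit of the assay: the limit of > 20000 nM in this assay, at which 1 of the 3 values shown sits. Compound 3 gives a measured reading in this assay with a carbon-only non-aromatic ring at the chain end, so neither the aromatic ring nor the two oxygens of the departing group are required for activity in this series.

The swap removes the aromatic ring and the oxygens together, and it also makes the group smaller, so the compounds shown do not reveal which of these changes matters. A plain phenyl group at the same place would begin to separate them, while an amine or a longer chain there would test how much the chain end tolerates.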